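The source may hold more compounds than are shown below. What is called first, only, known or untested is meant among the compounds shown, and "the series" means these compounds.

Measured compounds in this series:

compound 1 `COc1ccc(C2=NN(C3=NC(=O)/C(=C4\C(=O)Nc5ccc(Br)cc54)S3)C(c3ccc(OC)cc3)C2)cc1` — 380 nM
compound 2 `COc1ccc(C2=NN(C3=NC(=O)/C(=C4\C(=O)Nc5ccc(Cl)cc54)S3)C(c3ccc(OC)cc3)C2)cc1` — 390 nM
compound 3 `COc1ccc(C2CC(c3ccc4ccccc4c3)=NN2C2=NC(=O)/C(=C3\C(=O)Nc4ccccc43)S2)cc1` — 13600 nM

In a functional assay on cells (Cancer cell lines, Homo sapiens) for cytotoxicity, read by sulforhodamine B assay, with a stated time of 48 h (a lower number here means a stronger inhibitor of growth, a higher number a weaker inhibitor of growth), compound 2 gives 390 nM. Its nearest neighbour is compound 1: the step of a 1.0-fold higher number from compound 1 to compound 2 (0.01 log units; within the scatter) is within the scatter, so the two numbers count as one. Compound 3 differs from compound 2 in several places. In this assay compound 3 gives 13600 nM, a far higher number, beyond the scatter.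

Compound 4 `COc1ccc(C2=NN(C3=NC(=O)/C(=C4\C(=O)Nc5ccc(Cl)cc54)S3)C(c3ccc(Cl)cc3)C2)cc1` is the next member. Its difference from compound 2 is chloro in place of methoxy on an aromatic carbon.

Within the data shown here, no measured step bears directly on this change. Among the measured compounds shown here, the only single-point step in hand, the step of a 1.0-fold higher number from compound 1 to compound 2 (0.01 log units; within the scatter), concerns the swap of one halogen for another on a different ring of the shared core and did not move the number beyond the scatter. Whether exchanging methoxy for chloro on the 4-methoxyphenyl ring carries a cost or a gain is therefore unknown, and the expectation rests on the neighbourhood alone: compound 4 is expected to stay near compound 2, with a step of a 1.2-fold higher number from compound 2 to compound 4 (0.06 log units; within the scatter) in this assay, and the range is kept wide to cover an unobserved change. The estimate for compound 4 is 450 nM, between 150 nM and 1500 nM.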

Compound 4, concentration for total growth inhibition: 460 nM
Estimate against measurement, compound 4: 1.0-fold (0.01 log units) below; the range from low to high includes it.
By their numbers in this assay, from the lowest: compounds 1, 2 and 4 (each within the scatter of the next); then compound 3.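

In this assay, among these compounds, the step of a 1.2-fold higher number from compound 2 to compound 4 (0.07 log units; within the scatter) gives the first reading at this position: the change from 4-methoxyphenyl to 4-chlorophenyl, with the group para to a large group, stays within the scatter, so methoxy and chloro count as one here in this single pair. This is a second single-place change that leaves the number in place, on a different part of the molecule from the chloro in place of bromo change read in the step of a 1.0-fold higher number from compound 1 to compound 2 (0.01 log units; within the scatter). Nothing measured is at hand to account for this result.

As far as these compounds go, only methoxy and chloro can be compared at this position, and it remains open whether an amine, a carboxylic acid or a longer chain such as butoxy would also stay within the scatter. Compound 3, at 13600 nM, differs from compound 2 in several places, and the compounds shown do not tell which of those differences goes with its far higher number.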